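Chain variation on the shared core, agonist read-out

This account rests on a few compounds, and the source may have more. Where it says the series, first, only, none or still open, it means among the compounds named here.

Of the compounds shown here, three on the shared core have been measured, differing only in the chain carried on the amine nitrogen. Compound 1 `c1ccc(CN(CCCCN(C[C@H]2Cc3ccccc3CN2)[C@H]2CCCc3cccnc32)Cc2ccccn2)nc1` in a functional assay on cells for agonist activity at C-X-C chemokine receptor type 4 (Homo sapiens), read by fluorescence and calcium flux, with a stated time of 90 s (a lower number here means that less compound is needed, a higher number that more compound is needed for the effect), gives > 30000 nM, which is a limit of the assay and not a number. Compound 2 `c1ccc2c(c1)CN[C@@H](CN(CCCCN(Cc1ccncc1)Cc1ccncc1)[C@H]1CCCc3cccnc31)C2` in this assay gives > 30000 nM, again a limit. Compound 3 `c1ccc2c(c1)CN[C@@H](CN(CCCCNCC1CCNCC1)[C@H]1CCCc3cccnc31)C2` in this assay gives > 30000 nM, also a limit. Compound 3 therefore stands only at a limit, with no number of its own; the same holds for every measured compound in the series, since (the limit of > 30000 nM in this assay, at which 3 of the 3 values shown sit).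

Compound 4 `C(=C/CN(C[C@H]1Cc2ccccc2CN1)[C@H]1CCCc2cccnc21)\CNC1CCOCC1` has not yet been measured in this assay. It differs from compound 3 by a group of 10 heavy atoms (8 carbon, 1 nitrogen, 1 oxygen; one six-membered non-aromatic ring with 1 hetero atom) in place of a group of 11 heavy atoms (9 carbon, 2 nitrogen; one six-membered non-aromatic ring with 1 hetero atom), on a saturated chain carbon bound to an amine nitrogen. Within the data shown here, no step between two measured compounds is available for comparison, so no direction can be read from the data; the expectation is that the step from compound 3 to compound 4 lies within the scatter, with a step that the limit leaves unreadable from compound 3 to compound 4 as the expected step. Compound 4 is estimated in this assay at 40000 nM, within a range of 8000 nM to 200000 nM, most probably reported again as a limit.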

Compound 4, half-maximal effective concentration: > 30000 nM
Compound 4: no number, only a limit; the forecaster's own chance of this, stated with the estimate: 80%; the middle value does not contradict the limit.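

The result for compound 4 in this assay is again a limit, as for compound 3, so no step can be read between compound 3 and compound 4: the limit of > 30000 nM in this assay, at which 4 of the 4 values shown sit.

The compounds shown leave open whether any chain on the shared core gives a measurable agonist value in this assay.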